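The source may hold more compounds than are shown below. What is called first, only, known or untested is meant among the compounds shown, and "the series" means these compounds.

Measured in a functional assay on OVCAR-3 cells (Homo sapiens) for antiproliferative activity, read by WST assay, with a stated time of 72 h, in the absence of a further agent; a lower number here means a stronger inhibitor, a higher number a weaker inhibitor:
compound 1 `CCCCCCCC/C=C\c1c(C)c(/C=C/CCCCCCCC)c2[n+](c1C)CCC2`: 900 nM
compound 2 `CCCCCCCC/C=C\c1c(C)c(/C=C\CCCCCCCC)c2[n+](c1C)CCC2`: 1100 nM
compound 3 `CCCCCCCCCCc1c(C)c(CCCCCCCCCC)c2[n+](c1C)CCC2`: 600 nM

Compound 1 holds the second highest of these three numbers; compound 2 sits nearest to it and compound 3 furthest, and both gaps fall within the scatter of this assay. Compound 4 `CCCCCCCC/C=C\c1c(C)c(/C=C/CCCCCCCC)c(C)[n+]2c1CCC2` has not yet been measured in this assay. Set against compound 1, it differs as follows: the two compounds have the same atoms and bonds and differ only in configuration as drawn: 2 of 2 stereo elements differ; a double bond is drawn E in compound 1 and Z in compound 4; a double bond is drawn Z in compound 1 and E in compound 4. For the measured compounds named here, the one measured step that bears on such a change is a 1.2-fold higher number from compound 1 to compound 2 (0.09 log units; within the scatter), a step resting on (the fact that compounds 1 and 2 differ only in the configuration as drawn). There, a single swap of a drawn double-bond configuration moved the number only within the scatter. Going by the values given here, compound 4 swaps both drawn configurations at once, and nothing among the measured compounds suggests that doing both should carry the number beyond the scatter. The step of a 1.1-fold higher number from compound 1 to compound 4 (0.05 log units; within the scatter) is therefore expected to be small, with no clear direction. Compound 4 is estimated at 1000 nM, within a range from 500 nM to 2000 nM.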

Compound 4, half-maximal inhibitory concentration: 900 nM
For compound 4 the middle estimate is 1.1-fold (0.05 log units) above the measured one, within the range that was stated.
By their numbers in this assay, from the lowest: compounds 3, 1, 4 and 2 (each within the scatter of the next).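

In this assay, for the compounds shown here, the change of both drawn double-bond configurations at once gives no change at the digits printed from compound 1 to compound 4 (within the scatter), so the double swap, which the earlier compounds did not cover, leaves the number as unmoved as the single swap did. The new single swap adds a second case of the same kind, with a 1.2-fold lower number from compound 2 to compound 4 (0.09 log units; within the scatter), which also stays within the scatter. Among compounds 1, 2 and 4, no drawn arrangement of the two double bonds separates from the others, and the comparison of compounds 1 and 4 rests on this: the fact that compounds 1 and 4 differ only in the configuration as drawn

The compounds shown leave open how the number would respond if a chain ended in an amine or a carboxylic acid, or if a longer chain took its place. They also leave open whether this insensitivity to drawn configuration would hold with either of those groups present.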